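Urea series on the shared core: butyl to cyclohexyl

This account rests on a few compounds, and the source may have more. Where it says the series, first, only, none or still open, it means among the compounds named here.

Measured so far:
Compound 1, `CCCCc1ccc(CN)c(=O)n1Cc1ccc(-c2ccccc2-c2nn[nH]n2)cc1`: 2.8%
Compound 2, `CCCCNC(=O)NCc1ccc(CCCC)n(Cc2ccc(-c3ccccc3-c3nn[nH]n3)cc2)c1=O`: 10.3%

In a functional assay on the whole organism (artery) for inhibition, with Rattus norvegicus as the target, at a dose of 3 mg/kg by the intraduodenal route (a higher number here means more inhibition at the dose given (going by the name of the read-out), a lower number less inhibition), compound 2 gives the higher of the two numbers, with compound 1 nearest; the step of a number 7.5 percentage points higher from compound 1 to compound 2 (within the scatter) is within the scatter, so no order between them can be claimed. Compound 3, `CCCCc1ccc(CNC(=O)NC2CCCCC2)c(=O)n1Cc1ccc(-c2ccccc2-c2nn[nH]n2)cc1`, differs from compound 2 by cyclohexyl in place of butyl on an amide-type nitrogen. Going by the values given here, no measured step exchanges one group for another on that amide-type nitrogen; the only step known, a number 7.5 percentage points higher from compound 1 to compound 2 (within the scatter), adds the urea and stays within the scatter. The expected step of a number 1.7 percentage points higher from compound 2 to compound 3 (within the scatter) is therefore none beyond the scatter. Compound 3 is estimated at 12%, range 0% to 30%.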

Compound 3, a percentage reported as inhibition, in the whole organism at one dose (the size of the read-out at that dose, not a potency): 0%
Estimate against measurement, compound 3: 12 percentage points above; the range from low to high includes it.
By their numbers in this assay, from the lowest: compounds 3, 1 and 2 (each within the scatter of the next, the first and the last beyond it).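

In this assay the group on the amide-type nitrogen now gives a step beyond the scatter: cyclohexyl in place of butyl gives a number 10.3 percentage points lower from compound 2 to compound 3 (beyond the scatter), though the step is modest. Against the free amine, cyclohexylcarbamoyl in place of hydrogen gives a number 2.8 percentage points lower from compound 1 to compound 3 (within the scatter), which stays within the scatter, so the cyclohexyl urea is not separated from compound 1. No measured evidence bears on the reason for either step. One exchange sets no trend on this nitrogen. Open, as far as these compounds go, is how a longer chain, a phenyl or a carboxylic acid there would read against butyl and cyclohexyl.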